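Swapping 3-hydroxybenzyl for 3,4-dihydroxyphenyl on compound 1

The compounds below may be only part of what the source reports. "The series", "measured", "known", "first", "only" and "open" are said of these compounds alone.

In a functional assay on HL-60 cells (Homo sapiens) for inhibition, read by CCK-8 assay, with a stated time of 48 h (a lower number here means a stronger inhibitor, a higher number a weaker inhibitor), the measured compounds give these values:
- Compound 1 `O=S(=O)(NCCNC(=S)Nc1cc(C(F)(F)F)cc(C(F)(F)F)c1)c1ccc(-c2ccccc2OCc2cccc(O)c2)s1` gives > 50000 nM as a limit
- Compound 2 `O=[N+]([O-])c1ccc(NC(=S)NCCNS(=O)(=O)c2ccc(-c3ccccc3O[C@H]3CC[C@@H](O)CC3)s2)cc1` gives > 50000 nM as a limit
- Compound 3 `COc1ccc(Oc2ccccc2-c2ccsc2S(=O)(=O)NCCNC(=S)Nc2cc(C(F)(F)F)cc(C(F)(F)F)c2)cc1OC` gives 2800 nM as a true number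

Compound 1 gives only a limit, > 50000 nM, and not a number. It therefore sits at the limit of > 50000 nM in this assay, at which 2 of the 3 values shown sit, and offers no exact starting point. The next molecule to consider is compound 4 `O=S(=O)(NCCNC(=S)Nc1cc(C(F)(F)F)cc(C(F)(F)F)c1)c1ccc(-c2ccccc2Oc2ccc(O)c(O)c2)s1`, which has not yet been measured. The change is 3,4-dihydroxyphenyl in place of 3-hydroxybenzyl on an oxygen on an aromatic ring, so 3,4-dihydroxyphenyl stands in place of 3-hydroxybenzyl on an oxygen on an aromatic ring.

For the measured compounds named here, no pair of measured compounds differs in just one place, so no measured step can serve as a guide. Going by the values given here, the only firm number comes from compound 3, whose 2800 nM shows that a measurable value is possible within this small set. A move toward stronger inhibition therefore seems more likely than none, though compound 4 may also stop at a limit. The expected change is an at least 5.5-fold lower number from compound 1 to compound 4 (0.74 log units; beyond the scatter), and this size is only an estimate. Compound 4 is estimated at 9000 nM with an expected range of 1500 nM to 50000 nM in this measurement.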

Compound 4, half-maximal inhibitory concentration: 18300 nM
Estimate against measurement, compound 4: 2.0-fold (0.31 log units) below, and the stated range covers the measured number.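

In this assay compound 1 gives > 50000 nM, which is a limit and not a number. Compound 4 gives 18300 nM, a true number at this position, and 3,4-dihydroxyphenyl in place of 3-hydroxybenzyl on an oxygen on an aromatic ring therefore produces an at least 2.7-fold lower number from compound 1 to compound 4 (0.43 log units; beyond the scatter). This fixes the direction of the change, but its size is only a minimum, with one end resting on a limit: the limit of > 50000 nM in this assay, at which 2 of the 4 values shown sit.

The swap alters two things together, removing the benzyl carbon and bringing in a second hydroxyl group, and the compounds shown do not tell which of the two goes with the lower number. Going by these compounds, it also remains open how this position would respond to a 3-hydroxyphenyl group, which would separate those two features, or to a phenyl ring carrying a carboxylic acid or an amine in place of the hydroxyl groups.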